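This account rests on a few compounds, and the source may have more. Where it says the series, first, only, none or still open, it means among the compounds named here.

Of the compounds shown here, three of a shared core have been measured in a functional assay on MGC-803 cells (Homo sapiens) for antiproliferative activity, read by CCK-8 assay, with a stated time of 72 h, tested at 2 uM; a higher number here means a stronger effect of the compound at the concentration tested, a lower number a weaker effect. Compound 1 `COc1ccc(N2CCN(C(=S)SCc3ccc(C(=O)Nc4ccccc4N)cc3)CC2)cc1` gives 25.3% in this assay, the lowest of the three numbers. Compound 3 `Nc1ccccc1NC(=O)c1ccc(CSC(=S)N2CCCC2)cc1` gives 27%, which lies within the scatter of compound 1. Compound 2 `CC1CCCCN1C(=S)SCc1ccc(C(=O)Nc2ccccc2N)cc1` gives 64.4%, well beyond the scatter above compound 1. Among the measured compounds shown here, the one step between neighbours, a number 37.4 percentage points lower from compound 2 to compound 3 (beyond the scatter), shows how much the group on the thiocarbonyl carbon can matter.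

Compound 4 `Nc1ccccc1NC(=O)c1ccc(CSC(=S)N2CCN(c3cnccn3)CC2)cc1` keeps the piperazine of compound 1 and changes only its far end: pyrazin-2-yl in place of 4-methoxyphenyl on an amine nitrogen in a ring. For the measured compounds named here, no measured step touches this place; the step from compound 2 to compound 3 concerns a different part of the molecule and is a guide only to how large changes here can be, not to their direction. The expectation for compound 4 is therefore centred near compound 1, as a number 4.7 percentage points higher from compound 1 to compound 4 (within the scatter), with a wide range. Compound 4 is estimated to give 30%, between 10% and 55%.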

Compound 4, a percentage reported as inhibition, at one concentration (the size of the read-out at that concentration, not a potency): 27.1%
The estimate for compound 4 lay 2.9 percentage points above the measured number; the measured number falls inside the stated range.
By their numbers in this assay, from the lowest: compounds 1, 3 and 4 (each within the scatter of the next); then compound 2.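

Pyrazin-2-yl in place of 4-methoxyphenyl on an amine nitrogen in a ring gives a number 1.8 percentage points higher from compound 1 to compound 4 (within the scatter) in this assay and so offers the first reading at this far end of the molecule. For this pair of groups, the exchange of one six-membered aromatic ring for another leaves the read-out within the scatter, unlike the large step on the thiocarbonyl carbon, a number 37.4 percentage points lower from compound 2 to compound 3 (beyond the scatter), at the other place. Nothing measured here bears on the reason for this result.

Both groups compared are six-membered aromatic rings, so this single pair cannot show how far the position tolerates change in general. On these data alone, it remains open whether the read-out would respond to a methyl group, a benzyl group or an acetyl group on that nitrogen.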